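Phenyl in place of cyclohexyl on the amine nitrogen

A few compounds are considered here, and "the series" means these few. Any claim that something is new, unique, unknown or untested is made for them only; others in the source may bear on it.

Of the compounds shown here, three sharing one core have been measured in a functional assay on MCF7 cells (Homo sapiens) for inhibition, read by sulforhodamine B assay; on this read-out higher numbers stand for weaker inhibition and lower numbers for stronger inhibition. Compound 1 `O=C1C(NC2CCCC2)=CC(=O)c2c1nc1n2[C@H]2OC[C@@H](O)[C@H]2OC1` gives only a limit of the assay, > 16000 nM. Compound 2 `Cc1ccc(NC2=CC(=O)c3c(nc4n3[C@H]3OC[C@@H](O)[C@H]3OC4)C2=O)cc1` likewise gives a limit, > 4000 nM. Compound 3 `O=C1C(NC2CCCCC2)=CC(=O)c2c1nc1n2[C@H]2OC[C@@H](O)[C@H]2OC1`, which carries a cyclohexyl on the amine nitrogen, also stands at a limit, > 16000 nM, so its true potency is not pinned down by a number. Because every value is a limit, the steps between them cannot be read: a step that the two limits leave unreadable from compound 1 to compound 2, a step that the two limits leave unreadable from compound 1 to compound 3 and a step that the two limits leave unreadable from compound 2 to compound 3. Among the compounds with values here, the only evidence is the limit of > 16000 nM in this assay, at which 2 of the 3 values shown sit, and (the limit of > 4000 nM in this assay, at which 1 of the 3 values shown sits).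

The next compound, compound 4 `O=C1C(Nc2ccccc2)=CC(=O)c2c1nc1n2[C@H]2OC[C@@H](O)[C@H]2OC1`, differs from compound 3 by phenyl in place of cyclohexyl on an amine nitrogen. Within the data shown here, the closest measured comparison, cyclohexyl against 4-methylphenyl, is itself unreadable, so no step of known size bears on this change. With all three neighbours at limits in this assay, compound 4 is expected to give weak inhibition too, and most likely only a limit again. The step from compound 3 to compound 4 is therefore estimated as a number no higher from compound 3 to compound 4 (the limit leaves the size open). Compound 4 is estimated at 16000 nM, within a range from 4000 nM to 60000 nM.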

Compound 4, half-maximal inhibitory concentration: > 4000 nM
Compound 4: no number, only a limit; the forecaster's own chance of this, stated with the estimate: 80%; the middle value lies beyond the limit too.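

In this assay compound 4 also stands only at a limit and not at a number, so none of the steps linking it to compound 1, compound 2 or compound 3 can be read. The compounds shown leave open how strongly any of them inhibits, and whether changing the group on the amine nitrogen alters that at all.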